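From isobutyl to cyclohexyl on the amide nitrogen

The source may report more compounds than this note shows. Statements on the series, on what has been measured and on what is new or still open speak of the compounds shown alone.

Measured so far in a functional assay on the whole organism with Mus musculus as the target; a lower number here means that less compound is needed, a higher number that more compound is needed for the effect:
Compound 1 `CC(C)NC(=O)CCC(=O)c1cccc(C(F)(F)F)c1`: > 150 mg/kg, a limit
Compound 2 `CC(C)CNC(=O)CCC(=O)c1cccc(C(F)(F)F)c1`: > 200 mg/kg, a limit

Compound 2 has no number in this assay, only the limit > 200 mg/kg. The one other result is also a limit, that of compound 1 at > 150 mg/kg.

The next compound, compound 3 `O=C(CCC(=O)c1cccc(C(F)(F)F)c1)NC1CCCCC1`, keeps the shared core and carries cyclohexyl in place of isobutyl on the amide-type nitrogen (cyclohexyl in place of isobutyl on an amide-type nitrogen). A single measured step bears on this change: a step that the two limits leave unreadable from compound 1 to compound 2, with isobutyl in place of isopropyl on the same nitrogen. Neither its size nor its direction can be read. Among the measured compounds shown here, with that step as the only guide, no shift beyond the usual scatter is expected in this assay, and another limit rather than a number is the more likely result. The expected change is a number no higher from compound 2 to compound 3 (the limit leaves the size open), which is an estimate only. For compound 3 the estimated value is 200 mg/kg, with an expected range from 90 mg/kg to 450 mg/kg.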

Compound 3, dose for half-maximal effect: > 200 mg/kg
Compound 3 was reported as a limit; the forecaster's own chance of this, stated with the estimate: 65%; the middle value lies on the limit itself.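

In this assay compound 3 gives > 200 mg/kg, which is a limit and not a number. Among the compounds shown here, with only limits for compound 1, compound 2 and compound 3, no step among them can be read. The compounds shown leave open whether changing the group on the amide-type nitrogen alters the dose needed in this assay.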